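A few compounds are considered here, and "the series" means these few. Any claim that something is new, unique, unknown or untested is made for them only; others in the source may bear on it.

Measured so far in a functional assay on Huh-7 cells (Homo sapiens) for inhibition, read by sulforhodamine B assay, with a stated time of 72 h; a higher number here means a weaker inhibitor, a lower number a stronger inhibitor:
compound 1 `O=C(/C=C/c1cn(-c2ccccc2)nc1-c1ccsc1)c1ccccc1` gives 4700 nM;
compound 2 `O=C(/C=C/c1cn(-c2ccccc2)nc1-c1cccnc1)c1ccccn1` gives 6400 nM;
compound 3 `COc1cc(OC)c(C(=O)/C=C/c2cn(-c3ccccc3)nc2-c2cccnc2)c(OC)c1` gives 500 nM.

Compound 2 holds the highest number of the three; compound 1 sits within the scatter of it, while compound 3 sits well beyond the scatter at a lower number.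

Compound 4 `COc1ccc(OC)c(C(=O)/C=C/c2cn(-c3ccccc3)nc2-c2cccnc2)c1` differs from compound 2 in one place: 2,5-dimethoxyphenyl in place of pyridin-2-yl on a carbonyl carbon. Going by the values given here, no measured pair isolates this change. Compound 3 is the nearest comparison, keeping the rest of the molecule of compound 2 unchanged, and in this assay compound 3 gives 500 nM. A step down in this assay from compound 2 to compound 4, beyond the scatter, is therefore expected, estimated as a 5.8-fold lower number from compound 2 to compound 4 (0.76 log units; beyond the scatter). Compound 4 is expected at 1100 nM, range 350 nM to 3500 nM.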

Compound 4, half-maximal inhibitory concentration: 1300 nM
Compound 4: middle estimate off by 1.2-fold (0.07 log units), on the low side; measured number inside the range.
By their numbers in this assay, from the lowest: compound 3; then compound 4; then compounds 1 and 2 (each within the scatter of the next).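

Going by these compounds alone, the first one-place step at this position, on a carbonyl carbon, is a 4.9-fold lower number from compound 2 to compound 4 (0.69 log units; beyond the scatter) in this assay, so the group held there moves the number beyond the scatter. The change replaces pyridin-2-yl with the larger 2,5-dimethoxyphenyl, and the larger group is tolerated here. No measurement shown accounts for the step.

On these data alone, the swap removes the ring nitrogen and adds the methoxy groups at once, so their separate shares stay open. Also open, as far as these compounds go, is how a phenyl ring with a single methoxy group, or one carrying an amine or a carboxylic acid, would fare here.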